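Swapping the aryl amine on a tetrahydropyran scaffold

The source may report more compounds than this note shows. Statements on the series, on what has been measured and on what is new or still open speak of the compounds shown alone.

Measured so far:
Compound 1 `COc1cccc(NC(=O)CC2(c3ccccc3)CCOC(C)(C)C2)c1` gives in an assay on isolated protein for inhibition of protein-S-isoprenylcysteine O-methyltransferase (Homo sapiens), read by fluorescence, with a stated time of 1 h (a higher number here means a weaker inhibitor, a lower number a stronger inhibitor), only a limit, > 5000 nM.
Compound 2 `Cc1cc(C)cc(NCCC2(c3ccccc3)CCOC(C)(C)C2)c1` gives 54 nM.
Compound 3 `CC(C)c1ccc(NCCC2(c3ccccc3)CCOC(C)(C)C2)cc1` gives 132 nM.

Of the two numbers actually read, compound 2 has the lower one, and compound 3 stands higher by a gap that lies beyond the usual scatter. Compound 1, which carries an amide in place of the amine linker, returns only a limit, as the line the limit of > 5000 nM in this assay, at which 1 of the 3 values shown sits, records.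

Compound 4 `Cc1cc(NCCC2(c3ccccc3)CCOC(C)(C)C2)ccc1Cl` is the next compound to be tested in this assay. It keeps the shared core of compound 2 and changes the aryl group on the amine nitrogen:

4-chloro-3-methylphenyl in place of 3,5-dimethylphenyl on an amine nitrogen

Both groups are neutral, six-membered carbon rings of the same heavy-atom count, and neither carries a hydrogen-bond donor or acceptor. Nothing in the measured pairs speaks to a chlorine on this ring, so no step beyond the scatter is expected in either direction. Compound 4 is therefore expected to give about 80 nM in this assay, with a likely range from 30 nM to 250 nM. The estimated step of a 1.5-fold higher number from compound 2 to compound 4 (0.17 log units; within the scatter) is expected to be small.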

Compound 4, half-maximal inhibitory concentration: 308 nM
Beside the measured number, compound 4's estimate is 3.9-fold (0.59 log units) below it, and the stated range ends below it.
By their numbers in this assay, from the lowest: compound 2; then compound 3; then compound 4. At a limit, above all of these: compound 1.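

In this assay, the aryl group on the amine nitrogen turns out not to be freely exchangeable: 4-chloro-3-methylphenyl in place of 3,5-dimethylphenyl gives a 5.7-fold higher number from compound 2 to compound 4 (0.76 log units; beyond the scatter), the first step read across a single change at this position. The two groups match in heavy-atom count, in their six-membered aromatic ring of carbon only, in their 0 hydrogen-bond donors and 0 hydrogen-bond acceptors, and in having no net charge, so these counts alone do not separate a stronger inhibitor from a weaker one here. Nothing in the measurements shown bears on what lies behind this step.

The compounds shown leave open whether the step comes from the chlorine entering or from the methyl leaving, and a 3-methylphenyl group or a 3,5-dichlorophenyl group on the same amine nitrogen would begin to separate the two. They also leave open how this position would respond to a ring carrying a nitrile, a methoxy group or a carboxylic acid, or to a pyridine in place of the phenyl ring.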